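Aryl swap on a triazole where every value is a limit

The source may hold more compounds than are shown below. What is called first, only, known or untested is meant among the compounds shown, and "the series" means these compounds.

Measured so far:
Compound 1, `N#CC1=C(N)Oc2c(c3nc4ccccc4nc3c3ccccc23)C12C(=O)N(Cc1cnnn1-c1ccccc1Cl)c1ccccc12`, gives > 50000 nM in a functional assay on HepG2 cells (Homo sapiens) for antiproliferative activity, read by MTT assay, with a stated time of 48 h (on this read-out lower numbers stand for stronger inhibition and higher numbers for weaker inhibition), which is a limit of the assay and not a number.
Compound 2, `Cc1cc(C)cc(-n2nncc2CN2C(=O)C3(C(C#N)=C(N)Oc4c3c3nc5ccccc5nc3c3ccccc43)c3ccccc32)c1`, gives > 50000 nM in this assay, again a limit.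
Compound 3, `COc1ccc(-n2nncc2CN2C(=O)C3(C(C#N)=C(N)Oc4c(N)cc5nc6ccccc6nc5c43)c3ccccc32)cc1`, gives > 50000 nM in this assay, also a limit.

Compound 3 therefore stands at the limit, and it is not alone there: the limit of > 50000 nM in this assay, at which 3 of the 3 values shown sit. Within the data shown here, the one step between measured compounds, a step that the two limits leave unreadable from compound 1 to compound 2, cannot be read, since both ends are limits. The change under study is 2,4,6-trimethylphenyl in place of 4-methoxyphenyl on an aromatic nitrogen, giving compound 4, `Cc1cc(C)c(-n2nncc2CN2C(=O)C3(C(C#N)=C(N)Oc4c(N)cc5nc6ccccc6nc5c43)c3ccccc32)c(C)c1`. Among the measured compounds shown here, no measured step bears on this change in a readable way, so nothing in the numbers points in either direction. With every measured compound sitting at the limit, compound 4 is expected to give a limit as well, estimated at 50000 nM with a range from 20000 nM to 100000 nM. The expected step of a number no higher from compound 3 to compound 4 (the limit leaves the size open) is thus no change that the assay could show.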

Compound 4, half-maximal inhibitory concentration: 48100 nM
For compound 4 the middle estimate is 1.0-fold (0.02 log units) above the measured one, within the range that was stated.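

Among these compounds, compound 4 gives 48100 nM in this assay, the first value in this set that is a number and not a limit of the assay. Putting 2,4,6-trimethylphenyl in place of 4-methoxyphenyl on this aromatic nitrogen of the triazole gives an at least 1.0-fold lower number from compound 3 to compound 4 (0.01 log units; that floor lies within the scatter), so the swap cannot be called a real gain in activity, and the value of compound 4 lies close to where the assay stops giving numbers: the limit of > 50000 nM in this assay, at which 3 of the 4 values shown sit.

The true size of this step cannot be read, and neither can the step between compound 1 and compound 2. Still open, on these data alone, is how a pyridyl ring or a cyclohexyl group on the same nitrogen would behave in this assay, and whether any group there can bring the number well down.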